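The compounds below may be only part of what the source reports. "The series", "measured", "known", "first", "only" and "open" are said of these compounds alone.

Series notes, measured so far:
compound 1 `C=C(Br)C(=O)Nc1ccc(C(=O)/C=C/c2cccc(OC)c2OC)cc1`: 550 nM
compound 2 `C=C(Br)C(=O)Nc1ccc(C(=O)/C=C/c2ccc(OC)c(OC)c2)cc1`: 1200 nM
compound 3 `C=C(Br)C(=O)Nc1ccc(C(=O)/C=C/c2ccc(OC)cc2OC)cc1`: 1200 nM

All three values come from a functional assay on FM3A cells (Mus musculus) for antiproliferative activity, with a stated time of 48 h (on this read-out lower numbers stand for stronger inhibition and higher numbers for weaker inhibition), and the compounds differ only in the placing of their methoxy groups on the shared core. Compound 3, at 1200 nM, is level with compound 2, at 1200 nM, within the scatter, and together they hold the highest number of the set. Compound 1, at 550 nM, has a lower number than compound 3, and that gap lies beyond the scatter.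

The next compound is compound 4 `C=C(Br)C(=O)Nc1ccc(C(=O)/C=C/c2ccc(OC)c(OC)c2OC)cc1`, which differs from compound 3 by methoxy in place of hydrogen on an aromatic carbon, ortho to two methoxy groups and meta to a large group. Within the data shown here, no measured pair in the set shows such an addition directly, so any expectation rests on the narrow spread of the values so far. With compound 1 at 550 nM as the lowest number, a small move towards lower numbers in this assay is expected, hardly beyond the scatter. The estimated change is a 1.5-fold lower number from compound 3 to compound 4 (0.18 log units; within the scatter) as the expected step. For compound 4 the expected value is 800 nM, with an estimated range from 300 nM to 2000 nM as its ends.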

Compound 4, half-maximal inhibitory concentration: 530 nM
Compound 4: middle estimate off by 1.5-fold (0.18 log units), on the high side, within the range that was stated.
By their numbers in this assay, from the lowest: compounds 4 and 1 (each within the scatter of the next); then compounds 2 and 3 (each within the scatter of the next).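

In this assay, methoxy in place of hydrogen on an aromatic carbon, ortho to two methoxy groups and meta to a large group, gives a 2.3-fold lower number from compound 3 to compound 4 (0.35 log units; beyond the scatter), and the same addition read from the other starting point gives a 2.3-fold lower number from compound 2 to compound 4 (0.35 log units; beyond the scatter), so two of the three steps to compound 4 lie beyond the scatter and the set now holds direct readings of this addition. The third reading goes against any simple rule that an added methoxy group always lowers the number: it is a 1.0-fold lower number from compound 1 to compound 4 (0.02 log units; within the scatter), within the scatter, which leaves compound 1 and compound 4 level, so the addition pays off from two of the starting compounds but not from the third. Nothing at hand gives a reason for this difference between the steps.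

Open, going by these compounds, is whether an amine, a hydroxyl group or a longer chain such as ethoxy at this position would give a number like that of compound 4, or whether the methoxy group itself matters there. Also open, on these data alone, is whether the steps seen in this one cell assay carry over to other cell lines.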